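Amine substituent swap on a shared tryptamine-type core

The source may report more compounds than this note shows. Statements on the series, on what has been measured and on what is new or still open speak of the compounds shown alone.

Measured compounds:
- compound 1, `CC(=O)Nc1ccc(CNC2CCN(CCCc3c[nH]c4ccc(-n5cnnc5)cc34)CC2)cc1`: 75%
- compound 2, `NC(=O)OC[C@H](NC1CCN(CCCc2c[nH]c3ccc(-n4cnnc4)cc23)CC1)c1ccccc1`: 73%

In a functional assay on CHO cells for activation of 5-hydroxytryptamine receptor 1D (Homo sapiens), read by GTPgammaS binding (on this read-out higher numbers stand for larger maximal responses and lower numbers for smaller maximal responses), compound 2 gives 73%, and compound 1 gives 75%. Compound 2 has the lower of the two numbers, but its step to compound 1 is within the scatter: a number 2 percentage points lower from compound 1 to compound 2 (within the scatter). So on the numbers shown the two compounds cannot be told apart.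

Compound 3, `CC(CO)(NC1CCN(CCCc2c[nH]c3ccc(-n4cnnc4)cc23)CC1)c1ccccc1`, has not yet been measured in this assay. It differs from compound 2 in one place: 1-(hydroxymethyl)-1-phenylethyl in place of 2-(carbamoyloxy)-1-phenylethyl on an amine nitrogen. Among the compounds with values here, the only measured step, a number 2 percentage points lower from compound 1 to compound 2 (within the scatter), exchanged two quite different groups on the same amine nitrogen without moving the maximal response beyond the scatter. That step does not touch the part that changes here, the hydroxymethyl for the carbamoyloxy and the added methyl on the same carbon, so it is only loosely related. With nothing in the data pointing to a change in either direction, no step beyond the scatter is expected in this assay. The expected step is a number 3 percentage points lower from compound 2 to compound 3 (within the scatter). Compound 3 is therefore estimated to give 70%, with a range from 50% to 88%.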

Compound 3, largest response reached (reported as efficacy), in percent of the reference or control that the assay uses: 59%
For compound 3 the middle estimate is 11 percentage points above the measured one, within the range that was stated.
By their numbers in this assay, from the lowest: compound 3; then compounds 2 and 1 (each within the scatter of the next).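

Until now the substituent on this amine nitrogen seemed to matter little in this assay, but the new result shows that the maximal response can depend on it, with a number 14 percentage points lower from compound 2 to compound 3 (beyond the scatter) and a number 16 percentage points lower from compound 1 to compound 3 (beyond the scatter). The change from 2-(carbamoyloxy)-1-phenylethyl to 1-(hydroxymethyl)-1-phenylethyl alters two features at once: a hydroxymethyl takes the place of the carbamoyloxy end, and a methyl is added on the carbon that carries the phenyl ring, which also removes the defined stereocentre of compound 2. No measurement here explains why the response falls.

The compounds shown leave open which of these two features accounts for the step, and a 2-hydroxy-1-phenylethyl group on the same nitrogen, carrying the hydroxyl but not the added methyl, would help separate them. Going by these compounds, it also remains open how a group ending in an amine or a carboxylic acid at this place would behave on this read-out, and whether the lower response is specific to this one substituent.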